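The source may report more compounds than this note shows. Statements on the series, on what has been measured and on what is new or still open speak of the compounds shown alone.

Compound 3 `CC(=O)OC[C@H]1O[C@@H](n2cc(CN3C(=O)/C(=C\c4ccc(C)cc4)c4ccccc43)nn2)[C@H](OC(C)=O)[C@@H](OC(C)=O)[C@@H]1OC(C)=O` is one of three compounds of a shared core carrying a tetra-acetylated sugar, all tested in a functional assay on A549 cells (Homo sapiens) for cytotoxicity, read by sulforhodamine B assay, with a stated time of 48 h; on this read-out higher numbers stand for weaker inhibition and lower numbers for stronger inhibition. In this assay compound 3 gives 16500 nM. Its closest neighbour is compound 2 `CC(=O)OC[C@H]1O[C@@H](n2cc(CN3C(=O)/C(=C/c4ccc(C)cc4)c4ccccc43)nn2)[C@H](OC(C)=O)[C@@H](OC(C)=O)[C@@H]1OC(C)=O`, which differs only in the configuration of the exocyclic double bond and gives 16000 nM; the step of a 1.0-fold higher number from compound 2 to compound 3 (0.01 log units; within the scatter) is within the scatter, so the two values cannot be told apart. Compound 1 `COc1ccc2c(c1)c(/C=C1/C(=O)Nc3ccc(F)cc31)cn2Cc1cn([C@@H]2O[C@H](COC(C)=O)[C@@H](OC(C)=O)[C@H](OC(C)=O)[C@H]2OC(C)=O)nn1`, bearing a methoxy group and a fluorine on its core, reaches only the limit of the assay at > 200000 nM; this is a limit and not a number.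

Compound 4 `CC(=O)OC[C@H]1O[C@@H](n2cc(CN3C(=O)/C(=C\c4ccc5ccccc5c4)c4ccccc43)nn2)[C@H](OC(C)=O)[C@@H](OC(C)=O)[C@@H]1OC(C)=O` is not yet measured. It differs from compound 3 by naphthalen-2-yl in place of 4-methylphenyl on a double-bonded chain carbon bound to a double-bonded ring carbon. Within the data shown here, of the measured steps, only that from compound 2 to compound 3 involves the same part of the molecule, and it concerns geometry rather than the aryl group, so it bears on the present change only loosely. Among the measured compounds shown here, no measured step replaces one aromatic group by another, so there is no direct guide to the size of this step. Compound 4 is therefore expected to give about 13000 nM, with a range from 3500 nM to 50000 nM. The expected step of a 1.3-fold lower number from compound 3 to compound 4 (0.10 log units; within the scatter) is thus estimated to stay within the scatter or somewhat below it.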

Compound 4, half-maximal inhibitory concentration: 62200 nM
Compound 4: the middle estimate sits 4.8-fold (0.68 log units) below what was measured; the measured number lies above the stated range.
By their numbers in this assay, from the lowest: compounds 2 and 3 (each within the scatter of the next); then compound 4. At a limit, above all of these: compound 1.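

In this assay, the group at this place proves able to shift the read-out: the step of a 3.8-fold higher number from compound 3 to compound 4 (0.58 log units; beyond the scatter) lies beyond the scatter, whereas changing only the double-bond geometry gave a 1.0-fold higher number from compound 2 to compound 3 (0.01 log units; within the scatter), which lies within it. The earlier compounds shown here showed only that the drawn geometry made no measurable difference for the 4-methylphenyl pair; here, replacing 4-methylphenyl with naphthalen-2-yl, which adds a second six-membered aromatic ring of carbon, gives a modestly higher number and so weaker inhibition. This rests on a single pair, so it sets no trend, and nothing measured here accounts for the step.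

The compounds shown leave open whether compound 4 would also keep its value on reversal of the double-bond geometry, as the 4-methylphenyl pair did. They also leave open how an unsubstituted phenyl, a 4-methoxyphenyl or a 4-aminophenyl group at the same place would compare, and so whether the second ring or some other feature of naphthalen-2-yl goes with the higher number.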